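Methoxy in Place of Methyl on the Fused Ring

The compounds below may be only part of what the source reports. "The series", "measured", "known", "first", "only" and "open" are said of these compounds alone.

Compound 3 `Cc1cccc2c1CN(C(=O)c1cc(S(C)(=O)=O)ccc1O[C@@H](C)C(F)(F)F)C2` gives 3360 nM in an assay on CHO cells for inhibition of sodium- and chloride-dependent glycine transporter 1 (Homo sapiens), read by scintillation counting (a higher number here means that more compound is needed for the effect, a lower number that less compound is needed), the highest of the three numbers seen so far, though its gap to compound 1 `C[C@H](Oc1ccc(S(C)(=O)=O)cc1C(=O)N1Cc2ccccc2C1)C(F)(F)F`, which gives 2540 nM, lies within the scatter, while compound 2 `C[C@H](Oc1ccc(S(C)(=O)=O)cc1C(=O)N1Cc2ccc(C(F)(F)F)cc2C1)C(F)(F)F` gives 21 nM. Compound 4 `COc1cccc2c1CN(C(=O)c1cc(S(C)(=O)=O)ccc1O[C@@H](C)C(F)(F)F)C2` differs from compound 3 in one respect: methoxy in place of methyl on an aromatic carbon. Among the measured compounds shown here, two measured steps touch the same fused ring. a 1.3-fold higher number from compound 1 to compound 3 (0.12 log units; within the scatter), so a methyl there left the number essentially unchanged. a 120-fold lower number from compound 1 to compound 2 (2.08 log units; beyond the scatter), but that trifluoromethyl sits elsewhere on the ring and is not a methoxy, so it offers no direct guide. For the measured compounds named here, no measured compound carries a methoxy, so the step from methyl to methoxy rests on the methyl result alone. Since the methyl step was within the scatter, a methoxy at the same place is expected to bring a step that is none beyond the scatter, in either direction. The expected step of a 1.1-fold lower number from compound 3 to compound 4 (0.05 log units; within the scatter) is thus estimated to stay within the scatter. Compound 4 is therefore expected to give about 3000 nM in this assay, with a range from 1000 nM to 9000 nM.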

Compound 4, half-maximal effective concentration in the sodium- and chloride-dependent glycine transporter 1 assay: 1940 nM
Compound 4: the middle estimate sits 1.5-fold (0.19 log units) above what was measured; low and high end bracket the measured number.
By their numbers in the sodium- and chloride-dependent glycine transporter 1 assay, from the lowest: compound 2; then compounds 4, 1 and 3 (each within the scatter of the next).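

In the sodium- and chloride-dependent glycine transporter 1 assay, compound 4 gives 1940 nM, and methoxy at this aromatic carbon behaves as methyl did, with a 1.7-fold lower number from compound 3 to compound 4 (0.24 log units; within the scatter) and a 1.3-fold lower number from compound 1 to compound 4 (0.12 log units; within the scatter), so hydrogen, methyl and methoxy here cannot be told apart in this assay. The same exchange of methyl for methoxy also stays within the scatter in a physicochemical assay for solubility (on this read-out lower numbers stand for lower solubility and higher numbers for higher solubility), where compound 3 gives 73 ug/mL and compound 4 gives 85 ug/mL, with a 1.2-fold higher number from compound 3 to compound 4 (0.07 log units; within the scatter), so it separates compound 3 and compound 4 on neither read-out. Nothing available accounts for this tolerance at the position.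

Going by these compounds, it remains open whether a trifluoromethyl at this same carbon would bring a step like the one elsewhere on the ring in the sodium- and chloride-dependent glycine transporter 1 assay, a 120-fold lower number from compound 1 to compound 2 (2.08 log units; beyond the scatter). Also open, on these data alone, is what a nitrile, an amine or a longer alkoxy chain would do at this carbon.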